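The source may report more compounds than this note shows. Statements on the series, on what has been measured and on what is new or still open speak of the compounds shown alone.

Measured compounds:
Compound 1, `Cc1ccc(N2CCN(CC(=O)N(c3ccccc3)c3ccccc3)CC2)cc1`, gives 31.2 mg/kg in a functional assay on the whole organism (strain Swiss albino) for inhibition, with Mus musculus as the target, with stated times of 30 min, 10 min and 20 min; a higher number here means that more compound is needed for the effect, a lower number that less compound is needed.
Compound 2, `O=C(CN1CCN(c2cccc(C(F)(F)F)c2)CC1)N(c1ccccc1)c1ccccc1`, gives 30 mg/kg in this assay.

Compound 2 holds the lowest of the two numbers in this assay, but its nearest neighbour, compound 1, lies within the scatter of it, so the two cannot be ranked. Among the compounds with values here, the only measured step, a 1.0-fold lower number from compound 1 to compound 2 (0.02 log units; within the scatter), swaps one aryl group on the ring nitrogen for another without moving the number. Compound 3, `O=C(CN1CCN(c2ccc(F)cc2)CC1)N(c1ccccc1)c1ccccc1`, continues this pattern: 4-fluorophenyl in place of 3-(trifluoromethyl)phenyl on an amine nitrogen in a ring. Because a 1.0-fold lower number from compound 1 to compound 2 (0.02 log units; within the scatter) showed no effect of exchanging the aryl group at this position, the same place in compound 3 is expected to tolerate the third aryl group equally, and the step of no change at the digits printed from compound 2 to compound 3 (within the scatter) is expected to stay within the scatter. Compound 3 is therefore estimated at 30 mg/kg in this assay, with a plausible range of 15 mg/kg to 60 mg/kg.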

Compound 3, dose for half-maximal effect: 20 mg/kg
For compound 3 the middle estimate is 1.5-fold (0.18 log units) above the measured one; measured number inside the range.
By their numbers in this assay, from the lowest: compounds 3, 2 and 1 (each within the scatter of the next).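

In this assay a third aryl group on the amine nitrogen in a ring still separates nothing: 4-fluorophenyl in place of 3-(trifluoromethyl)phenyl gives a 1.5-fold lower number from compound 2 to compound 3 (0.18 log units; within the scatter) and fluoro in place of methyl on an aromatic carbon gives a 1.6-fold lower number from compound 1 to compound 3 (0.19 log units; within the scatter) in this series. With both new steps inside the scatter, all three compounds now stand within the scatter of one another, so this position has accepted a single fluoro group on the phenyl ring as readily as the methyl and trifluoromethyl groups. Nothing at hand accounts for how close these numbers lie.

As far as these compounds go, it remains open whether this nitrogen would hold anything other than a substituted phenyl ring, such as a pyridine ring, a phenyl ring bearing a carboxylic acid, or a plain alkyl chain. From the compounds shown here alone, whether a change elsewhere would move the number also stays open, since all three compounds share the rest of the core of compound 1.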